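Ring contraction in the hydroxycycloalkylamino series

The compounds below may be only part of what the source reports. "The series", "measured", "known", "first", "only" and "open" are said of these compounds alone.

Compound 1 `COc1cc[nH]c1/C=C1\C(=O)Nc2ccc([N+](=O)[O-])c(N[C@H]3CC[C@H](O)CC3)c21`: 8550 nM
Compound 2 `COc1cc[nH]c1/C=C1\C(=O)Nc2ccc([N+](=O)[O-])c(N3CCC(O)CC3)c21`: 46 nM
Compound 3 `COc1cc[nH]c1/C=C1\C(=O)Nc2ccc([N+](=O)[O-])c(N3CCC(N)CC3)c21`: a limit of < 10 nM

In a functional assay on MDA-MB-435 cells (Homo sapiens) for antiproliferative activity, read by MTT assay, with a stated time of 5 days (on this read-out lower numbers stand for stronger inhibition and higher numbers for weaker inhibition), compound 1 gives 8550 nM, the highest number among the two that are not limits. Compound 2 sits far lower, a 190-fold lower number from compound 1 to compound 2 (2.27 log units; beyond the scatter). For compound 3 the read-out is only a limit, (the limit of < 10 nM in this assay, at which 1 of the 3 values shown sits). Compound 4 `COc1cc[nH]c1/C=C1\C(=O)Nc2ccc([N+](=O)[O-])c(N[C@H]3CC[C@H](O)C3)c21` differs from compound 1 by a single change: 3-hydroxycyclopentyl in place of 4-hydroxycyclohexyl on a nitrogen on an aromatic ring. Among the measured compounds shown here, none of the measured steps touches this change; the two steps from compound 1 both replace the whole amino-linked ring with a piperidinyl, and the step from compound 2 to compound 3 swaps a hydroxy for an amino. For the measured compounds named here, with no bearing step, compound 4 is expected to stay within the scatter of compound 1, giving an estimated step of a 1.1-fold lower number from compound 1 to compound 4 (0.03 log units; within the scatter). Compound 4 is thus estimated at 8000 nM, between 2500 nM and 30000 nM.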

Compound 4, half-maximal inhibitory concentration: 1000 nM
The estimate for compound 4 lay 8.0-fold (0.90 log units) above the measured number, and the stated range ends above it.
By their numbers in this assay, from the lowest: compound 2; then compound 4; then compound 1. At a limit, below all of these: compound 3.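

Contracting the ring while keeping the amino link does move the number at this position: an 8.6-fold lower number from compound 1 to compound 4 (0.93 log units; beyond the scatter), so 3-hydroxycyclopentyl in place of 4-hydroxycyclohexyl matters on its own. The (3-hydroxycyclopentyl)amino group still falls short of 4-hydroxypiperidin-1-yl, with a 22-fold higher number from compound 2 to compound 4 (1.34 log units; beyond the scatter), and of 4-aminopiperidin-1-yl, with an at least 100-fold higher number from compound 3 to compound 4 (2.00 log units; beyond the scatter). The value of compound 3 is a limit, not a number: the limit of < 10 nM in this assay, at which 1 of the 4 values shown sits.

Open, from the compounds shown here alone, is whether an amine in place of the hydroxy on the cyclopentyl ring would lower the number as it does on the piperidinyl ring. Also open, going by these compounds, is how the opposite arrangement at the two stereocentres of the cyclopentyl ring would read.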